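Ether series: hydrogen in place of fluoro

This account rests on a few compounds, and the source may have more. Where it says the series, first, only, none or still open, it means among the compounds named here.

Measured so far:
compound 1 `Cn1c(=O)[nH]c2ccc(OCc3ccc(Cl)cc3)cc21` — 8.29%
compound 2 `Cn1c(=O)[nH]c2ccc(OCc3cccc(F)c3)cc21` — 5.36%

In an assay on cells for inhibition of Amine oxidase [flavin-containing] B (Homo sapiens), read by fluorescence, with stated times of 30 min and 15 min, tested at 1 uM (a lower number here means less inhibition, a higher number more inhibition at the concentration tested (going by the name of the read-out)), compound 1 gives 8.29% and compound 2 gives 5.36%. Compound 2 carries the lower of the two numbers, but the gap to compound 1 lies within the scatter of repeated measurements, so the two compounds cannot be told apart on these data; both show only weak inhibition at the concentration tested.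

Compound 3 `Cn1c(=O)[nH]c2ccc(OCc3ccccc3)cc21` has not yet been run in this assay. Its difference from compound 2 is hydrogen in place of fluoro on an aromatic carbon. The change is small: a single heavy atom leaves and nothing beyond a hydrogen atom enters, on the same six-membered aromatic ring.

With no measured step of this kind in the series, the expectation for the step from compound 2 to compound 3 is none beyond the scatter, in either direction: a number 0.6 percentage points higher from compound 2 to compound 3 (within the scatter). Compound 3 is therefore estimated at 6%, with a range from -5% to 17%, resting on the value of compound 2, 5.36%, and the weak signal of compound 1.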

Compound 3, a percentage reported as inhibition, at one concentration (the size of the read-out at that concentration, not a potency): "not active" (no number reported)
No number was reported for compound 3, and the estimate cannot be compared.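

Going by these compounds alone, compound 3 is recorded as "not active" in this assay with no number reported, so no step from compound 2 to compound 3 can be read. No available evidence bears on this result. The compounds shown leave open what size of change, if any, hydrogen in place of fluoro produces in this read-out.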